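This account rests on a few compounds, and the source may have more. Where it says the series, first, only, none or still open, it means among the compounds named here.

In a physicochemical assay for metabolic stability, at 50 degrees C, tested at 5 uM (a higher number here means that the compound lasts longer, a lower number that the compound disappears faster), compound 1 `Cc1ccc(CO[P@@]2(=O)OC[C@H]3O[C@@H](n4cnc5c(N)ncnc54)[C@H](O)[C@@H]3O2)cc1` gives 0.1 h, compound 2 `Nc1ncnc2c1ncn2[C@@H]1O[C@@H]2CO[P@](=O)(OCc3ccc([N+](=O)[O-])cc3)O[C@H]2[C@H]1O` gives 240 h and compound 3 `Nc1ncnc2c1ncn2[C@@H]1O[C@@H]2CO[P@@](=O)(OCc3ccccc3[N+](=O)[O-])O[C@H]2[C@H]1O` gives 83 h. Compound 3 thus holds the middle of the three numbers, closer to compound 2 than to compound 1. Compound 4 `Nc1ncnc2c1ncn2[C@@H]1O[C@@H]2CO[P@](=O)(OCc3ccccc3[N+](=O)[O-])O[C@H]2[C@H]1O` is its counterpart at phosphorus: the two compounds have the same atoms and bonds and differ only in configuration as drawn: 1 of 5 stereo elements differ; a stereocentre at a phosphorus is drawn R in compound 3 and S in compound 4. Within the data shown here, the only measured step, a 2400-fold higher number from compound 1 to compound 2 (3.38 log units; beyond the scatter), was large, but it puts nitro in place of methyl on an aromatic carbon, so it says nothing direct about this change. Among the measured compounds shown here, no measured pair isolates a change of configuration at phosphorus. With the atoms and bonds unchanged, a step of that size is not expected here. The data also argue for no direction, so the expectation is a step within the scatter, held with a wide margin. The estimated step is a 1.1-fold higher number from compound 3 to compound 4 (0.04 log units; within the scatter). The half-life of compound 4 is expected to be 90 h, with an estimated range of 25 h to 320 h.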

Compound 4, half-life: 300 h
Beside the measured number, compound 4's estimate is 3.3-fold (0.52 log units) below it; the range from low to high includes it.
By their numbers in this assay, from the lowest: compound 1; then compound 3; then compounds 2 and 4 (each within the scatter of the next).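

No earlier pair isolated a change at phosphorus, and a 3.6-fold higher number from compound 3 to compound 4 (0.56 log units; beyond the scatter) now shows that in this assay this change alone can shift the half-life beyond the scatter, a shift that can be tied to a single difference: the fact that compounds 3 and 4 differ only in the configuration as drawn

The step with 2-nitrophenyl in place of 4-nitrophenyl, a 1.3-fold higher number from compound 2 to compound 4 (0.10 log units; within the scatter), stays within the scatter, so that pair cannot be ordered. The step with 2-nitrophenyl in place of 4-methylphenyl, a 3000-fold higher number from compound 1 to compound 4 (3.48 log units; beyond the scatter), is large.

Going by these compounds, whether a change of configuration at phosphorus has a similar effect with 4-nitrophenyl or 4-methylphenyl remains open. So does what an amine or a methoxy group in place of the nitro group would do to the half-life.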